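A Phenethylsulfanyl Side Chain on a Trifluoromethylpyridine Core

The source may report more compounds than this note shows. Statements on the series, on what has been measured and on what is new or still open speak of the compounds shown alone.

For the measured compounds named here, compound 1 `CC1CCN(CCCSc2nc(C(F)(F)F)ccc2CNC(=O)C(C)c2ccc(NS(C)(=O)=O)c(F)c2)CC1` is, of the two measured compounds, the one with the lowest number in an assay on CHO-K1 cells for antagonist activity at transient receptor potential cation channel subfamily V member 1 (Homo sapiens), read by FLIPR (a higher number here means a weaker inhibitor, a lower number a stronger inhibitor), where compound 1 gives 2.9 nM. Its nearest neighbour is compound 2 `COC(=O)CCSc1nc(C(F)(F)F)ccc1CNC(=O)C(C)c1ccc(NS(C)(=O)=O)c(F)c1`, which in this assay gives 48.2 nM; the step of a 17-fold higher number from compound 1 to compound 2 (1.22 log units; beyond the scatter) is large and replaces the (4-methylpiperidin-1-yl)methyl group with methoxycarbonyl on a saturated chain carbon, two bonds along the chain from a sulfur.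

Compound 3 `CC(C(=O)NCc1ccc(C(F)(F)F)nc1SCCc1ccccc1)c1ccc(NS(C)(=O)=O)c(F)c1` has not yet been measured in this assay. It differs from compound 1 as follows: phenyl in place of (4-methylpiperidin-1-yl)methyl on a saturated chain carbon, two bonds along the chain from a sulfur. Going by the values given here, the only measured step that touches the same place is the one from compound 1 to compound 2, and it was large; it removes the same (4-methylpiperidin-1-yl)methyl group, but what enters there is methoxycarbonyl rather than phenyl, so it bears on compound 3 only in part. Among the compounds with values here, a loss beyond the scatter is therefore expected, though probably smaller than the one to compound 2.

For compound 3 the estimated step is a 5.2-fold higher number from compound 1 to compound 3 (0.71 log units; beyond the scatter). Compound 3 is thus expected to give about 15 nM in this assay, within a range from 4 nM to 60 nM.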

Compound 3, inhibition constant: 1.9 nM
Estimate against measurement, compound 3: 7.9-fold (0.90 log units) above; measured number outside the range, below it.
By their numbers in this assay, from the lowest: compounds 3 and 1 (each within the scatter of the next); then compound 2.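

In this assay, phenyl in place of (4-methylpiperidin-1-yl)methyl on a saturated chain carbon, two bonds along the chain from a sulfur, gives a 1.5-fold lower number from compound 1 to compound 3 (0.18 log units; within the scatter) and so leaves the two groups indistinguishable here, although one holds a six-membered non-aromatic ring with a nitrogen and the other a six-membered aromatic ring of carbon only. The large loss seen with compound 2 is therefore not tied to the removal of the (4-methylpiperidin-1-yl)methyl group as such, for phenyl in place of methoxycarbonyl at the same place gives a 25-fold lower number from compound 2 to compound 3 (1.40 log units; beyond the scatter) and sets methoxycarbonyl apart from both ring-bearing groups among these three compounds. Nothing measured here accounts for the difference between methoxycarbonyl and the two ring-bearing groups.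

The compounds shown leave open whether a carboxylic acid, a simple open-chain amine or a longer chain ending in phenyl at this place would fall with compound 1 and compound 3 or with compound 2. They also leave open whether a ring is needed there at all, which a plain alkyl chain in place of phenyl would test.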